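The compounds below may be only part of what the source reports. "The series", "measured", "known", "first", "only" and "open" are said of these compounds alone.

Compound 1 `CCOC(=O)C(=O)Nc1cccc(N(C)C)c1C#N` gives 0.2 mg/kg
Compound 2 `CCOC(=O)C(=O)Nc1cccc(NC)c1C#N` gives 0.2 mg/kg
Compound 3 `CCNc1cccc(NC(=O)C(=O)OCC)c1C#N` gives 0.03 mg/kg

All three values come from a functional assay on the whole organism with Rattus norvegicus as the target (on this read-out higher numbers stand for an effect only at larger amounts of compound and lower numbers for an effect already at smaller amounts), and share one core, differing only in the amino group. Compound 3 has the lowest number of the three, so it shows its effect at the smallest dose, and its gap to each of the others lies beyond the scatter.

The next compound is compound 4 `CCCNc1cccc(NC(=O)C(=O)OCC)c1C#N`, which has propylamino where compound 3 has ethylamino. The change is methyl in place of hydrogen on a saturated chain carbon, two bonds along the chain from a nitrogen on an aromatic ring and it extends the chain at its far end.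

Among the measured compounds shown here, the closest precedent is a 6.7-fold lower number from compound 2 to compound 3 (0.82 log units; beyond the scatter) and this also placed a methyl on the chain, turning methylamino into ethylamino. A second step, no change at the digits printed from compound 1 to compound 2 (within the scatter), shows that another small change on the same nitrogen can leave the number unchanged. No chain longer than ethyl has been measured, so one favourable step cannot show whether further lengthening helps or harms. No direction is therefore favoured, and the uncertainty is wide on both sides.

The expected change is no change at the digits printed from compound 3 to compound 4 (within the scatter) and so no shift beyond the scatter is predicted. For compound 4 the estimated value is 0.03 mg/kg, with an expected range from 0.008 mg/kg to 0.12 mg/kg.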

Compound 4, dose for half-maximal effect: 0.5 mg/kg
Estimate against measurement, compound 4: 17-fold (1.22 log units) below; the measured number lies above the stated range.
By their numbers in this assay, from the lowest: compound 3; then compounds 1 and 2 (each within the scatter of the next); then compound 4.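

In this assay, the length of the chain on this nitrogen turns out to matter sharply, and not in one direction. The methyl added at the far end of ethylamino gives a 17-fold higher number from compound 3 to compound 4 (1.22 log units; beyond the scatter), whereas the earlier methyl added to methylamino gave a 6.7-fold lower number from compound 2 to compound 3 (0.82 log units; beyond the scatter), so among these compounds ethylamino marks a narrow low point, and the same kind of small addition can move the number either way. Propylamino also does more than lose the gain seen with ethylamino, since it lands past both smaller amino groups, with a 2.5-fold higher number from compound 2 to compound 4 (0.40 log units; beyond the scatter) and a 2.5-fold higher number from compound 1 to compound 4 (0.40 log units; beyond the scatter); nothing shown gives a measured reason for this reversal.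

The compounds shown leave open whether the number keeps rising with a longer chain such as butylamino, and whether a branched group such as isopropylamino, or a small ring such as cyclopropylamino, behaves like ethylamino or like propylamino. They also leave open whether ethylamino keeps its advantage when the ethyl ester at the other end of the shared core is replaced by a carboxylic acid.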